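This account rests on a few compounds, and the source may have more. Where it says the series, first, only, none or still open, it means among the compounds named here.

Series notes. Compound 1 `c1cc(N2CCCCC2)nc(Nc2ccc(Oc3ncnc4sccc34)cc2)n1` carries hydrogen on the aromatic-ring nitrogen and in a functional assay on HCT-116 cells (Homo sapiens) for inhibition, read by MTT assay, with a stated time of 72 h, tested at 20 uM (a higher number here means more inhibition at the concentration tested (going by the name of the read-out), a lower number less inhibition), compound 1 gives 66.3%. Compound 2 `CN(c1ccc(Oc2ncnc3sccc23)cc1)c1nccc(N2CCCCC2)n1` differs from it by methyl in place of hydrogen on a nitrogen on an aromatic ring, and in this assay compound 2 gives 52.2%, which is a number 14.1 percentage points lower from compound 1 to compound 2 (beyond the scatter). Among the two numbers measured so far compound 2 stands lowest, with compound 1 as its only neighbour.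

Compound 3 `CN(c1ccc(Oc2ncnc3sccc23)cc1)c1nccc(N2CCc3ccccc32)n1` keeps the methyl of compound 2 and changes the other end of the core: 2,3-dihydro-1H-indol-1-yl in place of piperidin-1-yl on an aromatic carbon. Within the data shown here, no measured step touches this position or this exchange of rings; the single step in hand, the methylation from compound 1 to compound 2, is a different change and gives no guide to size or direction here. Among the measured compounds shown here, the expectation therefore rests on compound 2 alone, with wide uncertainty and no step expected beyond the scatter, so a number 2.2 percentage points lower from compound 2 to compound 3 (within the scatter). For compound 3 the estimate in this assay is 50%, ranging from 25% to 75%.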

Compound 3, a percentage reported as inhibition, at one concentration (the size of the read-out at that concentration, not a potency): 20%
The estimate for compound 3 lay 30 percentage points above the measured number; measured number outside the range, below it.
By their numbers in this assay, from the lowest: compound 3; then compound 2; then compound 1.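

In this assay the group on this aromatic carbon of the shared core proves to matter: 2,3-dihydro-1H-indol-1-yl in place of piperidin-1-yl gives a number 32.2 percentage points lower from compound 2 to compound 3 (beyond the scatter) as the first step read at this position. The entering group brings a five-membered non-aromatic ring and a six-membered aromatic ring of carbon only, while the counts of hydrogen-bond donors and acceptors and the net charge stay the same as for piperidin-1-yl. No evidence at hand bears on why the number falls with this exchange.

On these data alone, whether morpholin-4-yl or an open-chain dimethylamino group at this carbon would stay near compound 2 remains open. Also open, as far as these compounds go, is whether 2,3-dihydro-1H-indol-1-yl would give a similar step with hydrogen on the aromatic-ring nitrogen, as in compound 1.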